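The compounds below may be only part of what the source reports. "The series", "measured", "known", "first", "only" and "open" are said of these compounds alone.

Working notes on the benzylsulfanyl series.

Of the compounds shown here, three of the shared core have numbers so far. Compound 1 `Cc1cc(S(=O)(=O)/N=C(\N)n2nccc2-c2ccccc2)c(SCc2cccc3ccccc23)cc1Cl` gives 0.268 h in an ADME assay on microsomes from liver (Homo sapiens) for metabolic stability, read by LC-MS, using NADPH, tested at 5 uM; on this read-out lower numbers stand for a shorter-lived compound and higher numbers for a longer-lived compound. Compound 2 `Cc1cc(S(=O)(=O)/N=C(\N)n2nccc2-c2ccccc2)c(SCc2ccccc2C)cc1Cl` gives 0.0802 h in this assay. Compound 3 `Cc1cc(S(=O)(=O)/N=C(\N)n2nccc2-c2ccccc2)c(SCc2cccc(C(F)(F)F)c2)cc1Cl` gives 0.0863 h in this assay, the second highest of the three numbers; its nearest neighbour is compound 2, with a 1.1-fold higher number from compound 2 to compound 3 (0.03 log units; within the scatter), and its furthest is compound 1, with a 3.1-fold lower number from compound 1 to compound 3 (0.49 log units; beyond the scatter).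

Compound 4 `Cc1cc(S(=O)(=O)/N=C(\N)n2nccc2-c2ccccc2)c(SCc2ccccc2C(F)(F)F)cc1Cl` is not yet measured. The change is 2-(trifluoromethyl)phenyl in place of 3-(trifluoromethyl)phenyl on a saturated chain carbon bound to a sulfur. For the measured compounds named here, no measured step swaps the two trifluoromethylphenyl groups directly. The steps of a 3.3-fold lower number from compound 1 to compound 2 (0.52 log units; beyond the scatter) and a 3.1-fold lower number from compound 1 to compound 3 (0.49 log units; beyond the scatter) both removed the naphthalen-1-yl group and are of modest size, while a 1.1-fold higher number from compound 2 to compound 3 (0.03 log units; within the scatter) shows that exchanging one substituted phenyl for another at this carbon stayed within the scatter. A step within the scatter is therefore expected here, with no clear direction, because a 1.1-fold higher number from compound 2 to compound 3 (0.03 log units; within the scatter) gave no shift beyond the scatter.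

The expected step is a 1.0-fold higher number from compound 3 to compound 4 (0.02 log units; within the scatter). Compound 4 is estimated at 0.09 h, within a range of 0.045 h to 0.18 h.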

Compound 4, half-life: 0.15 h
The estimate for compound 4 lay 1.7-fold (0.22 log units) below the measured number, within the range that was stated.
By their numbers in this assay, from the lowest: compounds 2, 3, 4 and 1 (each within the scatter of the next, the first and the last beyond it).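

Working from the two trifluoromethyl placements, the swap of 3-(trifluoromethyl)phenyl for 2-(trifluoromethyl)phenyl on a saturated chain carbon bound to a sulfur gives a 1.7-fold higher number from compound 3 to compound 4 (0.24 log units; within the scatter) in this assay, so this assay does not separate the two placements. Trifluoromethyl in place of methyl on an aromatic carbon gives a 1.9-fold higher number from compound 2 to compound 4 (0.27 log units; within the scatter) and is likewise not resolved. Unlike compound 2 and compound 3, which each stand beyond the scatter of compound 1, the 2-(trifluoromethyl)phenyl group gives a 1.8-fold lower number from compound 1 to compound 4 (0.25 log units; within the scatter), so at this position compound 4 is separated neither from naphthalen-1-yl nor from the other substituted phenyl groups.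

No measurement at hand accounts for any of these steps. It remains open whether a phenyl group carrying an amine or a carboxylic acid at this carbon would stand beyond the scatter of these compounds.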